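Compound 3: cyclopropyl amide in place of the acylsulfonamide

The source may report more compounds than this note shows. Statements on the series, on what has been measured and on what is new or still open speak of the compounds shown alone.

Among the measured compounds shown here, compound 1 `COc1ccc2cccc(CCC(=O)NS(C)(=O)=O)c2n1` gives 5 nM in an assay on cells for displacement of a labelled ligand from melatonin receptor type 1A (Homo sapiens), with a stated time of 120 min; a higher number here means a weaker inhibitor, a lower number a stronger inhibitor; compound 2 `CCS(=O)(=O)NC(=O)CCc1cccc2ccc(OC)nc12` gives 16 nM, the higher of the two numbers measured so far. For the measured compounds named here, the only step recorded, a 3.2-fold higher number from compound 1 to compound 2 (0.51 log units; beyond the scatter), concerns the chain on the sulfonyl sulfur. Going by the values given here, compound 3 `COc1ccc2cccc(CCC(=O)NC3CC3)c2n1` differs from compound 2 by cyclopropyl in place of ethylsulfonyl on an amide-type nitrogen, a change no measured pair covers, so the step from compound 2 to compound 3 can only be guessed broadly. For compound 3 the expected outcome in this assay is 10 nM, with a range of 2 nM to 60 nM, which corresponds to an expected step of a 1.6-fold lower number from compound 2 to compound 3 (0.20 log units; within the scatter).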

Compound 3, inhibition constant: 34 nM
Estimate against measurement, compound 3: 3.4-fold (0.53 log units) below; low and high end bracket the measured number.
By their numbers in this assay, from the lowest: compound 1; then compound 2; then compound 3.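

In this assay cyclopropyl in place of ethylsulfonyl on an amide-type nitrogen gives a 2.1-fold higher number from compound 2 to compound 3 (0.33 log units; beyond the scatter) and cyclopropyl in place of methylsulfonyl gives a 6.8-fold higher number from compound 1 to compound 3 (0.83 log units; beyond the scatter) on the same nitrogen. The earlier step changed only the chain on the sulfonyl sulfur, whereas these steps show that this nitrogen can carry a group without sulfonyl, though with a higher number than either sulfonyl compound. No data here explain either step.

Open, on these data alone, is how an acetyl group or a cyclobutyl ring would read on this nitrogen. As far as these compounds go, a propyl chain on the sulfonyl sulfur also remains open.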